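Ethoxy gives way to pentafluoroethyl

A few compounds are considered here, and "the series" means these few. Any claim that something is new, unique, unknown or untested is made for them only; others in the source may bear on it.

In an ADME assay on microsomes from liver (Rattus norvegicus, strain Sprague-Dawley) for metabolic stability, read by HPLC, using NADPH, with stated times of 5 min and 60 min, tested at 10 uM (on this read-out higher numbers stand for fast clearance and lower numbers for slow clearance), compound 1 (`CS(=O)(=O)Nc1ccc(CNC(=O)c2ccc(C34CC(C3)C4)cc2)c(Cl)c1`) gives 17 mL.min-1.g-1 and compound 2 (`CCOc1ccc(C(=O)NCc2ccc(NS(C)(=O)=O)cc2Cl)cc1`) gives 12 mL.min-1.g-1. Within the data shown here, these two numbers lie within the usual scatter of each other, so compound 2 stands level with the only other compound measured so far.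

Compound 3 (`CS(=O)(=O)Nc1ccc(CNC(=O)c2ccc(C(F)(F)C(F)(F)F)cc2)c(Cl)c1`) carries 1,1,2,2,2-pentafluoroethyl in place of ethoxy on an aromatic carbon.

Among the measured compounds shown here, one measured step bears on this change: a 1.4-fold lower number from compound 1 to compound 2 (0.15 log units; within the scatter). It exchanges the group on that same aromatic carbon and stays within the scatter. For the measured compounds named here, no measured compound carries pentafluoroethyl, so this single step is thin guidance. A step beyond the scatter is therefore not expected in this assay, in either direction.

The estimated change is a 1.2-fold lower number from compound 2 to compound 3 (0.08 log units; within the scatter). Compound 3 is expected at 10 mL.min-1.g-1, with an estimated range of 4 mL.min-1.g-1 to 25 mL.min-1.g-1.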

Compound 3, intrinsic clearance in microsomes: 14 mL.min-1.g-1
Beside the measured number, compound 3's estimate is 1.4-fold (0.15 log units) below it, within the range that was stated.
By their numbers in this assay, from the lowest: compounds 2, 3 and 1 (each within the scatter of the next).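

In this assay, 1,1,2,2,2-pentafluoroethyl in place of ethoxy on this aromatic carbon, para to a large group, leaves the read-out within the scatter (a 1.2-fold higher number from compound 2 to compound 3 (0.07 log units; within the scatter)). The exchange of the group with two four-membered rings for pentafluoroethyl at the same place also stays within the scatter (a 1.2-fold lower number from compound 1 to compound 3 (0.08 log units; within the scatter)). Three groups that differ in heavy atoms, rings and hydrogen-bond acceptors therefore read level here, and no measurement at hand explains why.

As far as these compounds go, whether an amine or a carboxylic acid on this carbon would carry the read-out beyond the scatter remains open. So does whether a longer chain, such as butoxy, would stay level with ethoxy and pentafluoroethyl.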